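A few compounds are considered here, and "the series" means these few. Any claim that something is new, unique, unknown or untested is made for them only; others in the source may bear on it.

Three compounds have been measured so far in an assay on CHO cells for displacement of a labelled ligand from adenosine receptor A1 (Homo sapiens), read by scintillation counting, with a stated time of 120 min, tested at 10 uM; a lower number here means less inhibition, a higher number more inhibition at the concentration tested (going by the name of the read-out):

Compound 1, `Nc1scc(CN2CCN(c3ccc(F)cc3Cl)CC2)c1C(=O)c1ccc(Cl)cc1`, gives 0%.
Compound 2, `Nc1scc(CN2CCN(c3cccc(C(F)(F)F)c3)CC2)c1C(=O)c1ccc(Cl)cc1`, gives 0%.
Compound 3, `Nc1scc(CN2CCN(c3cc(Cl)ccc3Cl)CC2)c1C(=O)c1ccc(Cl)cc1`, gives 0%.

Compound 3 therefore stands level with compounds 1 and 2, and none of the three shows inhibition at the concentration tested. The steps among them all concern the group on the amine nitrogen in the ring, and each is flat: no change at the digits printed from compound 1 to compound 2 (within the scatter), no change at the digits printed from compound 1 to compound 3 (within the scatter) and no change at the digits printed from compound 2 to compound 3 (within the scatter).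

Compound 4, `Nc1scc(CN2CCN(c3ccc(Cl)c(Cl)c3)CC2)c1C(=O)c1ccc(Cl)cc1`, has not yet been measured. It differs from compound 3 in one place: 3,4-dichlorophenyl in place of 2,5-dichlorophenyl on an amine nitrogen in a ring. Every measured step in this assay bears on that kind of change, since each swaps one such group for another on the same ring nitrogen, and none moved the read-out beyond the scatter. Compound 4 is therefore expected to show no inhibition either, with a step of no change at the digits printed from compound 3 to compound 4 (within the scatter) expected from compound 3. The estimate for compound 4 is 0%, between -8% and 12%.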

Compound 4, a percentage reported as inhibition, at one concentration (the size of the read-out at that concentration, not a potency): 1%
For compound 4 the middle estimate is 1 percentage points below the measured one, and the stated range covers the measured number.
By their numbers in this assay, from the lowest: compounds 1, 2, 3 and 4 (each within the scatter of the next).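

In this assay, the change from 2,5-dichlorophenyl to 3,4-dichlorophenyl keeps the same atoms and only joins them differently, and it gives a number 1 percentage points higher from compound 3 to compound 4 (within the scatter), so rearranging the two chlorines on this ring adds no separation that the earlier swaps of differing groups had failed to show. The comparisons with the other two groups agree, with a number 1 percentage points higher from compound 2 to compound 4 (within the scatter) and a number 1 percentage points higher from compound 1 to compound 4 (within the scatter), so all four substituted phenyl groups on the ring nitrogen remain indistinguishable in this assay. Nothing available accounts for this flat result.

Going by these compounds, all four compounds carry a phenyl group bearing only halogen or trifluoromethyl on that nitrogen, so it remains open whether an amine or a carboxylic acid on the phenyl, or a longer chain in its place, would move the read-out. The shared core also stays the same throughout, leaving the effect of any change elsewhere on it unknown.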